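Anilino variation at the shared core: compound 3 to compound 4

This account rests on a few compounds, and the source may have more. Where it says the series, first, only, none or still open, it means among the compounds named here.

Three members of the series have numbers in a functional assay on B16-F10 cells (Mus musculus) for inhibition, read by MTT assay, with a stated time of 72 h; a lower number here means a stronger inhibitor, a higher number a weaker inhibitor. Compound 1 `N#Cc1c(Nc2ccccc2Cl)nc(SCc2cn(Cc3ccccc3Cl)nn2)nc1-c1ccccc1` gives 8350 nM. Compound 2 `COc1ccccc1Nc1nc(SCc2cn(Cc3ccccc3Cl)nn2)nc(-c2ccccc2)c1C#N` gives 7860 nM, and the step of a 1.1-fold lower number from compound 1 to compound 2 (0.03 log units; within the scatter) places compound 1 and compound 2 within the scatter of each other. Compound 3 `N#Cc1c(Nc2cccc([N+](=O)[O-])c2)nc(SCc2cn(Cc3ccccc3Cl)nn2)nc1-c1ccccc1` gives 17200 nM, the highest number of the three, with a 2.1-fold higher number from compound 1 to compound 3 (0.31 log units; beyond the scatter) and a 2.2-fold higher number from compound 2 to compound 3 (0.34 log units; beyond the scatter) both modest and beyond the scatter.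

Compound 4 `N#Cc1c(Nc2ccc(F)cc2)nc(SCc2cn(Cc3ccccc3Cl)nn2)nc1-c1ccccc1` is not yet measured. The change from compound 3 is 4-fluorophenyl in place of 3-nitrophenyl on a nitrogen on an aromatic ring. Within the data shown here, no measured step involves 4-fluorophenyl, so the bearing steps are only those in which 3-nitrophenyl replaces another substituted phenyl on the same nitrogen, and both raised the number modestly. Reversing that direction, a modest fall back toward the numbers of compound 1 and compound 2 is expected, and the expected step is a 1.9-fold lower number from compound 3 to compound 4 (0.28 log units; within the scatter). For compound 4 in this assay the estimate is 9000 nM, with a range from 4500 nM to 18000 nM.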

Compound 4, half-maximal inhibitory concentration: 5340 nM
The estimate for compound 4 lay 1.7-fold (0.23 log units) above the measured number, within the range that was stated.
By their numbers in this assay, from the lowest: compounds 4, 2 and 1 (each within the scatter of the next); then compound 3.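

In this assay, the change from 3-nitrophenyl to 4-fluorophenyl gives a 3.2-fold lower number from compound 3 to compound 4 (0.51 log units; beyond the scatter), so the higher number of compound 3 is not shared by a phenyl group of a new substitution type on this nitrogen. The steps of a 1.5-fold lower number from compound 2 to compound 4 (0.17 log units; within the scatter) and a 1.6-fold lower number from compound 1 to compound 4 (0.19 log units; within the scatter) leave these three compounds unseparated, and among the four anilino groups shown, only the 3-nitrophenyl of compound 3 stands apart. Nothing available bears on what lies behind these differences.

The groups 3-nitrophenyl and 4-fluorophenyl differ in both the substituent and its ring position, so 4-nitrophenyl and 3-fluorophenyl are needed to tell these apart. Also open, going by these compounds, is how a phenyl carrying an amine or a carboxylic acid would read at this nitrogen.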